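A few compounds are considered here, and "the series" means these few. Any claim that something is new, unique, unknown or untested is made for them only; others in the source may bear on it.

Measured compounds:
- Compound 1, `CCC1=C(O)c2c(oc(-c3cccc(C)c3)cc2=O)C(CC)(CC)C1=O`: 49.7 uM
- Compound 2, `CCC1=C(O)c2c(oc(-c3ccc(OC)c(OC)c3OC)cc2=O)C(CC)(CC)C1=O`: 9.4 uM
- Compound 3, `CCC1=C(O)c2c(oc(-c3cc(Cl)c(OC)c(OC)c3)cc2=O)C(CC)(CC)C1=O`: 21.8 uM

These three share one core and differ only in the aromatic ring attached to it. In a functional assay on KB cells (Homo sapiens) for antiproliferative activity, read by sulforhodamine B assay, with a stated time of 3 days (on this read-out lower numbers stand for an effect already at smaller amounts and higher numbers for an effect only at larger amounts of compound), compound 1 gives the highest number of the three. Its nearest neighbour is compound 3 at 21.8 uM, a gap beyond the scatter, and the furthest is compound 2 at 9.4 uM, also beyond the scatter. So compound 1 needs the largest amount of the three to reach the measured effect.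

Compound 4, `CCC1=C(O)c2c(oc(-c3cc(C)ccc3C)cc2=O)C(CC)(CC)C1=O`, has not yet been measured in this assay. It differs from compound 1 in one place: methyl in place of hydrogen on an aromatic carbon. For the measured compounds named here, nothing among the measured compounds shows what a single added methyl on this ring does, since compounds 2 and 3 carry different substituents altogether. A methyl is a small, uncharged group without donors or acceptors, so a modest step is expected, possibly towards a lower number but not far beyond the scatter.

For compound 4 the estimate is 40 uM, within 15 uM to 110 uM, which means an expected step of a 1.2-fold lower number from compound 1 to compound 4 (0.09 log units; within the scatter).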

Compound 4, concentration for half-maximal effect: 14.5 uM
Compound 4: middle estimate off by 2.8-fold (0.44 log units), on the high side; measured number outside the range, below it.
By their numbers in this assay, from the lowest: compounds 2, 4 and 3 (each within the scatter of the next, the first and the last beyond it); then compound 1.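

In this assay, for the compounds shown here, compounds 1 and 4 form the first pair that differs in only one place, and the added methyl gives a 3.4-fold lower number from compound 1 to compound 4 (0.53 log units; beyond the scatter). Going by these compounds alone, this shows that the ring position ortho to a large group and para to a methyl group is not indifferent: going from 3-methylphenyl to 2,5-dimethylphenyl, a change of one carbon atom, moves the number beyond the scatter, which the earlier compounds could not show, as none of them differs from another in just one place. Nothing measured here explains why this single methyl has that effect.

Going by these compounds, it remains open whether the lower number is specific to methyl or would also appear with another group in the same place, such as an ethyl chain, an amine or a carboxylic acid. On these data alone, it is also open whether a methyl in this place would give a step of similar size on a ring that lacks the other methyl, so this one step cannot yet be read as a general rule for the series.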